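The source may report more compounds than this note shows. Statements on the series, on what has been measured and on what is new or still open speak of the compounds shown alone.

Compound 1 `CC(C)(C)[Si](C)(C)O[C@H]1CCCO[C@@H]1CO`: > 100000 nM (a limit)
Compound 2 `CC(C)(C)[Si](C)(C)O[C@@H]1CCCO[C@@H]1CO`: > 100000 nM (a limit)

In a functional assay on A2780 cells (Homo sapiens) for antiproliferative activity, read by sulforhodamine B assay, with a stated time of 48 h (on this read-out lower numbers stand for stronger inhibition of growth and higher numbers for weaker inhibition of growth), compound 1 gives > 100000 nM, which is a limit of the assay and not a number. Compound 2 gives > 100000 nM, also a limit, so it has no exact starting value. Compound 3 `CC(C)(C)[Si](C)(C)O[C@@H]1CCCO[C@@H]1COCC(=O)O` differs from compound 2 by carboxymethyl in place of hydrogen on an oxygen on a saturated carbon, with carboxymethyl in place of hydrogen on an oxygen on a saturated carbon. Among the measured compounds shown here, the only measured step, a step that the two limits leave unreadable from compound 1 to compound 2, changes configuration alone and cannot be sized, given (the limit of > 100000 nM in this assay, at which 2 of the 2 values shown sit). It says nothing direct about this new group, so no clear gain in this assay is expected. The estimated step is a number no higher from compound 2 to compound 3 (the limit leaves the size open). For compound 3 the expected value is 100000 nM, with an estimated range of 40000 nM to 300000 nM.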

Compound 3, concentration for 50% growth inhibition: > 100000 nM
Compound 3: no number, only a limit; the forecaster's own chance of this, stated with the estimate: 85%; the middle value sits exactly at the limit.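

Compound 3, like compound 2, gives only a limit and not a number, so no size can be read for the step between them: the limit of > 100000 nM in this assay, at which 3 of the 3 values shown sit.

Going by these compounds, whether carboxymethyl in place of hydrogen changes growth inhibition at all remains open, as does the true strength of all three compounds.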